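The source may report more compounds than this note shows. Statements on the series, on what has been measured and on what is new or still open speak of the compounds shown alone.

Among the compounds with values here, compound 2 `CN(Cc1ccccc1Br)C(=O)c1cc2c(Cc3ccccc3)n[nH]c2cc1O` was tested in a functional assay on A2780 cells (Homo sapiens) for antiproliferative activity, read by resazurin assay, with a stated time of 72 h (a higher number here means a weaker inhibitor, a lower number a stronger inhibitor), where compound 2 gives 1200 nM, the lowest of the three numbers measured so far. Compound 1 `CN(Cc1ccccc1F)C(=O)c1cc2c(Cc3ccccc3)n[nH]c2cc1O` gives 1500 nM in this assay, and the step of a 1.3-fold lower number from compound 1 to compound 2 (0.10 log units; within the scatter) lies within the scatter, so these two cannot be told apart. Compound 3 `Cc1ccccc1CN(C)C(=O)c1cc2c(Cc3ccccc3)n[nH]c2cc1O` gives 4400 nM; the step of a 3.7-fold higher number from compound 2 to compound 3 (0.56 log units; beyond the scatter) is beyond the scatter, as is a 2.9-fold higher number from compound 1 to compound 3 (0.47 log units; beyond the scatter).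

Compound 4 `Cc1ccc(CN(C)C(=O)c2cc3c(Cc4ccccc4)n[nH]c3cc2O)cc1` has not yet been measured. Its change from compound 2 is 4-methylphenyl in place of 2-bromophenyl on a saturated chain carbon bound to an amide-type nitrogen. Within the data shown here, no measured step makes exactly this change: in compound 3 a methyl simply takes the place of the bromo on an aromatic carbon, whereas compound 4 carries a 4-methylphenyl group, a different arrangement of the same atoms. What the measured steps do show is that exchanging a halogen for a methyl on that ring raised the number by a modest amount, in a 3.7-fold higher number from compound 2 to compound 3 (0.56 log units; beyond the scatter) and in a 2.9-fold higher number from compound 1 to compound 3 (0.47 log units; beyond the scatter). Because of a 3.7-fold higher number from compound 2 to compound 3 (0.56 log units; beyond the scatter) a similar modest rise is expected for compound 4, although the different arrangement of the methyl leaves room for a smaller or a larger step. The expected step is a 2.9-fold higher number from compound 2 to compound 4 (0.46 log units; beyond the scatter). Compound 4 is estimated at 3500 nM, with a range from 1500 nM to 8000 nM.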

Compound 4, half-maximal inhibitory concentration: 6900 nM
Compound 4: middle estimate off by 2.0-fold (0.29 log units), on the low side; the range from low to high includes it.
By their numbers in this assay, from the lowest: compounds 2 and 1 (each within the scatter of the next); then compounds 3 and 4 (each within the scatter of the next).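

The step from 2-methylphenyl to 4-methylphenyl on the saturated chain carbon bound to an amide-type nitrogen gives a 1.6-fold higher number from compound 3 to compound 4 (0.20 log units; within the scatter), so in this assay these two methyl-bearing compounds cannot be told apart, and moving the methyl on this ring makes no readable difference here. Within the data shown here, compound 4 stands apart from both halogen-bearing compounds, with a 5.8-fold higher number from compound 2 to compound 4 (0.76 log units; beyond the scatter) and with a 4.6-fold higher number from compound 1 to compound 4 (0.66 log units; beyond the scatter), so the split between fluoro or bromo and methyl on this ring, seen earlier with only one methyl compound, now holds for two methyl compounds and none of the four goes against it. Nothing available explains this split.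

The compounds shown hold their halogens only as 2-fluorophenyl and 2-bromophenyl, so how a 4-bromophenyl group would compare with 4-methylphenyl at this place stays open. Also open, as far as these compounds go, is how the number would respond to a ring carrying an amine or a carboxylic acid, or to a longer chain in place of the 4-methylbenzyl group.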